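The source may hold more compounds than are shown below. What is called first, only, known or untested is meant among the compounds shown, and "the series" means these compounds.

Compound 3 `Nc1cccc(-c2cn3nc(-c4ccc(Cl)cc4)sc3n2)c1` gives 160000 nM in a functional assay on HeLa cells (Homo sapiens) for inhibition, read by cell counting, with a stated time of 4 days; a higher number here means a weaker inhibitor, a lower number a stronger inhibitor. Of the two compounds with a number in this assay, compound 3 has the higher one, and the nearest number belongs to compound 2 `Nc1cccc(-c2cn3nc(-c4ccccc4)sc3n2)c1`, which gives 26000 nM in this assay. Compound 1 `COc1ccc(-c2nn3cc(-c4cccc(N)c4)nc3s2)cc1` reaches only a limit in this assay, >= 250000 nM, and so sits at the limit of >= 250000 nM in this assay, at which 1 of the 3 values shown sits.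

Compound 4 `Nc1cccc(-c2cn3nc(-c4ccc(F)cc4)sc3n2)c1` differs from compound 3 in one place: fluoro in place of chloro on an aromatic carbon. The measured step that bears most directly on this change is a 6.2-fold higher number from compound 2 to compound 3 (0.79 log units; beyond the scatter), where a chloro was introduced at the same place; the step of an at least 1.5-fold lower number from compound 1 to compound 3 (0.19 log units; that floor lies within the scatter) also reaches this place, but it starts from a limit and tells little. The step of an at least 9.6-fold lower number from compound 1 to compound 2 (0.98 log units; beyond the scatter) shows that removing the methoxy from that position made a difference that is at least modest. Taken together, the chloro at this position cost potency against hydrogen, and compound 4 carries a fluoro there instead, so the expectation is that compound 4 falls between compound 2 and compound 3. The estimate for compound 4 is therefore 80000 nM, with a range from 25000 nM to 250000 nM, which corresponds to the step of a 2.0-fold lower number from compound 3 to compound 4 (0.30 log units; within the scatter) expected in this assay.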

Compound 4, half-maximal inhibitory concentration: >= 250000 nM
Compound 4: a limit, no number (the forecaster's own chance of this, stated with the estimate: 15%); at least 3.1-fold (0.49 log units) between middle value and limit.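

Compound 4 reaches only a limit in this assay, and it is the same limit that compound 1 reaches: the limit of >= 250000 nM in this assay, at which 2 of the 4 values shown sit. The earlier compounds showed that methoxy and chloro at this place each go with a higher number than hydrogen, and fluoro, the smallest change from hydrogen among these groups by name, now does the same, with an at least 9.6-fold higher number from compound 2 to compound 4 (0.98 log units; beyond the scatter); among the four compounds shown, none goes against this pattern, and hydrogen is the only group at this place with a number lower than all the others. Fluoro and chloro, however, are not separated by the step of an at least 1.5-fold higher number from compound 3 to compound 4 (0.19 log units; that floor lies within the scatter), so the change from 4-chlorophenyl to 4-fluorophenyl shows only that fluoro does not bring back what hydrogen gives.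

As far as these compounds go, with compound 1 and compound 4 both at a limit, the step between them cannot be read, and the order of fluoro and methoxy at this place stays open. Also open, from the compounds shown here alone, is whether any other group here, such as an amine, a carboxylic acid or a longer chain, would match or improve on hydrogen in this assay.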